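Spiroamine replaced by tetrahydroquinoline: solubility outlook

The compounds below may be only part of what the source reports. "The series", "measured", "known", "first", "only" and "open" are said of these compounds alone.

In a physicochemical assay for solubility, read by spectrophotometry, in phosphate buffer, with a stated time of 2 h, at pH 7.4 (a lower number here means a less soluble compound, a higher number a more soluble compound), compound 3 `COc1ccc2[nH]c(C(=O)N3CC(=O)N(Cc4ccccc4)[C@@H](CN4CC5(CCC5)C4)C3)cc2c1` gives 60700 nM, the highest of the two numbers in hand. Within the data shown here, compound 1 `COc1ccc2[nH]c(C(=O)N3CC(=O)N(Cc4ccccc4)[C@@H](CN4CCC5(CC4)CC5)C3)cc2c1` gives 28200 nM, and the step of a 2.2-fold higher number from compound 1 to compound 3 (0.33 log units; beyond the scatter) is the only readable step among the three. Compound 2 `COc1ccc2[nH]c(C(=O)N3CC(=O)N(Cc4ccccc4)[C@@H](CCN4CCC5(CC4)CC5)C3)cc2c1` is reported only as a limit, > 25000 nM, as recorded in the limit of > 25000 nM in this assay, at which 1 of the 3 values shown sits. The steps a step that the limit leaves unreadable from compound 1 to compound 2 and a step that the limit leaves unreadable from compound 2 to compound 3 are therefore not readable in size. Compound 4 `COc1ccc2[nH]c(C(=O)N3CC(=O)N(Cc4ccccc4)[C@@H](CN4CCCc5ccccc54)C3)cc2c1` differs from compound 3 by a group of 10 heavy atoms (9 carbon, 1 nitrogen; one six-membered non-aromatic ring with 1 hetero atom, one six-membered aromatic ring of carbon only) in place of a group of 7 heavy atoms (6 carbon, 1 nitrogen; one four-membered non-aromatic ring of carbon only, one four-membered non-aromatic ring with 1 hetero atom), on a saturated chain carbon bound to a saturated ring carbon. Among the measured compounds shown here, no measured step brings an aromatic ring into this place; the one readable step swapped one saturated spirocycle for another. The change to compound 4 is expected to give a lower number, estimated as a 6.1-fold lower number from compound 3 to compound 4 (0.78 log units; beyond the scatter). Compound 4 is thus estimated at 10000 nM, within 3000 nM to 40000 nM.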

Compound 4, solubility: 8500 nM
Estimate against measurement, compound 4: 1.2-fold (0.07 log units) above, and the stated range covers the measured number.
By their numbers in this assay, from the lowest: compound 4; then compound 1; then compound 3.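

In this assay, 1,2,3,4-tetrahydroquinolin-1-yl on this saturated chain carbon brings the first aromatic ring into the place and gives the lowest number of the series, with a 7.1-fold lower number from compound 3 to compound 4 (0.85 log units; beyond the scatter) and a 3.3-fold lower number from compound 1 to compound 4 (0.52 log units; beyond the scatter). Both steps are downward, so this replacement reads lower than either saturated spirocycle on the same one-carbon link. A third step, an at least 2.9-fold lower number from compound 2 to compound 4 (0.46 log units; beyond the scatter), starts from a limit: the limit of > 25000 nM in this assay, at which 1 of the 4 values shown sits.

The compounds shown do not separate the aromatic ring from the change in ring shape. Going by these compounds, how a plain piperidin-1-yl group, or a tetrahydroquinoline carrying a hydroxyl group, would read in this place stays open.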